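The compounds below may be only part of what the source reports. "The series", "measured", "known", "first", "only" and "open" are said of these compounds alone.

Measured in an ADME assay on the whole organism (Rattus norvegicus, strain Sprague-Dawley) for metabolic stability; a higher number here means that the compound lasts longer, a lower number that the compound disappears faster:
- Compound 1 `CC1(C)CC(c2c[nH]c3c(C(N)=O)cc(-c4ccccc4)cc23)CCS1(=O)=O`: 2.34 h
- Compound 2 `NC(=O)c1cc(-c2ccccc2)cc2c(C3CCS(=O)(=O)CC3)c[nH]c12`: 1.58 h

The values of compound 2 and compound 1 lie within the usual scatter of each other. Compound 3 `NC(=O)c1cc(-c2ccc(F)cc2)cc2c(C3CCS(=O)(=O)CC3)c[nH]c12` differs from compound 2 in one place, where phenyl becomes 4-fluorophenyl: fluoro in place of hydrogen on an aromatic carbon. This puts fluoro in place of hydrogen on an aromatic carbon, para to a large group. Among the compounds with values here, no measured pair shows this change, so the data give it no size, and no shift beyond the scatter is expected. The expected size is a 1.1-fold higher number from compound 2 to compound 3 (0.06 log units; within the scatter), within the scatter. The estimate for compound 3 is 1.8 h, with an expected range of 0.9 h to 3.6 h.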

Compound 3, half-life: 2.2 h
For compound 3 the middle estimate is 1.2-fold (0.09 log units) below the measured one, and the stated range covers the measured number.
By their numbers in this assay, from the lowest: compounds 2, 3 and 1 (each within the scatter of the next).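

Within the data shown here, putting fluoro in place of hydrogen on the phenyl group gives the first measured step at this position: in this assay it reads a 1.4-fold higher number from compound 2 to compound 3 (0.14 log units; within the scatter), so this pair shows no clear effect on half-life. This single step cannot show whether the same holds on other versions of the core. No supporting measurement here offers an explanation for the result.

On these data alone, whether an amine, a carboxylic acid or a methoxy group at this same place would shift the half-life beyond the usual scatter remains open.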